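This account rests on a few compounds, and the source may have more. Where it says the series, first, only, none or still open, it means among the compounds named here.

Measured in a functional assay on HL-60 cells (Homo sapiens) for inhibition, with a stated time of 72 h; on this read-out higher numbers stand for weaker inhibition and lower numbers for stronger inhibition:
Compound 1 `[N-]=[N+]=NCc1ncnc2c1ncn2[C@@H]1O[C@H](CO)[C@@H](O)[C@H]1O`: 1880 nM
Compound 2 `CN(Cc1ncnc2c1ncn2[C@@H]1O[C@H](CO)[C@@H](O)[C@H]1O)c1ccccc1`: 4000 nM
Compound 3 `OC[C@H]1O[C@@H](n2cnc3c(CSCc4ccccc4)ncnc32)[C@H](O)[C@@H]1O`: 10700 nM

Compound 3 has the highest number of the three, making it the weakest inhibitor here. Compound 4 `OC[C@H]1O[C@@H](n2cnc3c(COc4ccccn4)ncnc32)[C@H](O)[C@@H]1O` keeps the shared core, with (pyridin-2-yl)oxy in place of benzylsulfanyl on a saturated chain carbon bound to an aromatic carbon. No measurement covers this exact exchange, but three steps at that carbon bear on it: a 2.1-fold higher number from compound 1 to compound 2 (0.33 log units; beyond the scatter), a 2.7-fold higher number from compound 2 to compound 3 (0.43 log units; beyond the scatter) and a 5.7-fold higher number from compound 1 to compound 3 (0.76 log units; beyond the scatter). All were modest. With compound 3 at 10700 nM, the top of the series, a modest drop is expected in this assay. The expected change is a 2.1-fold lower number from compound 3 to compound 4 (0.33 log units; beyond the scatter) as a rough estimate. Compound 4 is estimated at 5000 nM, with an expected range from 1500 nM to 15000 nM in repeat measurements.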

Compound 4, half-maximal inhibitory concentration: 12000 nM
Compound 4: the middle estimate sits 2.4-fold (0.38 log units) below what was measured; low and high end bracket the measured number.
By their numbers in this assay, from the lowest: compound 1; then compound 2; then compounds 3 and 4 (each within the scatter of the next).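

In this assay, the benzylsulfanyl of compound 3 and the (pyridin-2-yl)oxy of compound 4 cannot be told apart (a 1.1-fold higher number from compound 3 to compound 4 (0.05 log units; within the scatter)), even though the two groups differ in their atoms. Compound 4 stands clearly apart from the other two (a 3.0-fold higher number from compound 2 to compound 4 (0.48 log units; beyond the scatter)) (a 6.4-fold higher number from compound 1 to compound 4 (0.81 log units; beyond the scatter)), so azido still gives the lowest number of the four. Nothing available explains these numbers.

On these data alone, whether a small primary amine or a carboxylic acid on that chain carbon would read nearer to compound 1 remains open. So does whether a plain phenoxy group would read like (pyridin-2-yl)oxy.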